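A few compounds are considered here, and "the series" means these few. Any claim that something is new, unique, unknown or untested is made for them only; others in the source may bear on it.

For the measured compounds named here, compound 2 `COc1ccc(-c2cn(C(=O)NCCCCc3ccccc3)c(=O)o2)cc1` gives 400 nM in an assay on isolated protein for inhibition of acid ceramidase (Homo sapiens), read by LC-MS, with a stated time of 1 h (a higher number here means a weaker inhibitor, a lower number a stronger inhibitor), the higher of the two numbers known so far; its nearest neighbour, compound 1 `O=C(NCCCCc1ccccc1)n1cc(-c2ccccc2)oc1=O`, gives 90 nM in this assay. Going by the values given here, the one measured step, a 4.4-fold higher number from compound 1 to compound 2 (0.65 log units; beyond the scatter), came with methoxy in place of hydrogen on an aromatic carbon. Compound 3 `COc1ccccc1-c1cn(C(=O)NCCCCc2ccccc2)c(=O)o1` has not yet been measured in this assay. It differs from compound 2 by 2-methoxyphenyl in place of 4-methoxyphenyl on an aromatic carbon. Among the compounds with values here, no measured step bears directly on moving the methoxy group within the ring, because a 4.4-fold higher number from compound 1 to compound 2 (0.65 log units; beyond the scatter) shows only what the methoxy costs at the place it occupies in compound 2, and nothing shows whether the new place bears it any better or worse. The expected step of a 1.3-fold lower number from compound 2 to compound 3 (0.12 log units; within the scatter) is therefore small, within the usual scatter, with wide uncertainty either way. Compound 3 is estimated at 300 nM, with a range from 80 nM to 1200 nM.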

Compound 3, half-maximal inhibitory concentration: 177 nM
Compound 3: middle estimate off by 1.7-fold (0.23 log units), on the high side; the range from low to high includes it.
By their numbers in this assay, from the lowest: compounds 1 and 3 (each within the scatter of the next); then compound 2.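

In this assay, for the compounds shown here, the place of the methoxy group on the ring proves to matter, which the earlier compounds could not show: 2-methoxyphenyl in place of 4-methoxyphenyl gives a 2.3-fold lower number from compound 2 to compound 3 (0.35 log units; beyond the scatter) at this aromatic carbon. Methoxy in place of hydrogen, taken as 2-methoxyphenyl, gives a 2.0-fold higher number from compound 1 to compound 3 (0.29 log units; within the scatter) and so stays within the scatter, whereas the same exchange as 4-methoxyphenyl went beyond it. Nothing measured here accounts for this difference between the two placements.

The compounds shown rest on only two placements of a single group, so it remains open whether the tolerance belongs to methoxy or to the place itself. A hydroxyl, an amine or a chlorine atom carried in the same place could answer that, and an ethoxy group would show whether a longer chain is borne there as well.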